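Methyl for methoxy on a chlorinated benzoxazole-type scaffold

The source may report more compounds than this note shows. Statements on the series, on what has been measured and on what is new or still open speak of the compounds shown alone.

Measured so far:
compound 1, `Cc1cccc2nc(N3CCN(C)CC3)oc12`, 5.48
compound 2, `COc1cc(Cl)cc2nc(N3CCN(C)CC3)oc12`, 6.16

Both compounds were tested in a functional assay on ileum (strain Hartley) for agonist activity at 5-hydroxytryptamine receptor 3A (Cavia porcellus); a lower number here means a less potent compound, a higher number a more potent compound, by a factor of ten per unit of this negative logarithm. In this assay compound 1 gives 5.48, and compound 2 gives 6.16. Within the data shown here, compound 2 thus holds the higher of the two numbers, and its distance to compound 1 is beyond the usual scatter; since the two structures differ in more than one place, no single step between them can be named.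

The next compound, compound 3 with the structure `Cc1cc(Cl)cc2nc(N3CCN(C)CC3)oc12`, has not yet been measured in this assay. It arises from compound 2 by a single change: methyl in place of methoxy on an aromatic carbon, the new group sitting on an aromatic carbon of a six-membered aromatic ring of carbon only, part of a fused system of two rings. Nothing measured here isolates the effect of this exchange, so the direction of the step is open. Compound 3 is expected to land somewhat below compound 2 while staying above compound 1. For compound 3 the expected step is a number 0.26 log units lower from compound 2 to compound 3 (within the scatter). The estimate for compound 3 is 5.9, with a range from 5.3 to 6.5.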

Compound 3, negative logarithm of the half-maximal effective concentration: 6.7
Compound 3: middle estimate off by 0.80 log units, on the low side; the measured number lies above the stated range.
By their numbers in this assay, from the lowest: compound 1; then compound 2; then compound 3.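

In this assay, methyl in place of methoxy on an aromatic carbon, ortho to a fused ring and meta to a chloro group, gives a number 0.54 log units higher from compound 2 to compound 3 (beyond the scatter) and so shows that at this position the methoxy group, with its oxygen and its hydrogen-bond acceptor, is not needed for a high number. Among these compounds, compound 3 also provides the first single-place comparison with compound 1: chloro in place of hydrogen on an aromatic carbon, with the methyl group kept, gives a number 1.22 log units higher from compound 1 to compound 3 (beyond the scatter) and is the larger of the two steps. Nothing given here accounts for either step.

The compounds shown leave open how an ethyl group, a hydroxyl group or an amine on this carbon would compare with methyl, and whether bromo or a nitrile could stand in place of the chloro group with a similar result. They also leave open whether methyl and methoxy would differ in the same direction on the core without the chloro group, as only the chlorinated pair can be read for this exchange.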